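The compounds below may be only part of what the source reports. "The series", "measured", "known", "first", "only" and "open" are said of these compounds alone.

Of the compounds shown here, three built on one shared core have been tested in a functional assay on A-431 cells (Homo sapiens) for cytotoxicity, read by MTT assay, with a stated time of 48 h; a higher number here means a weaker inhibitor, a lower number a stronger inhibitor. Compound 1 `CCCCCCCCCCCCCCNC(=O)[C@@H](NC(=O)c1cc2ccccc2o1)[C@@H](C)O` gives 20100 nM in this assay. Compound 2 `CCCCCCCCCCCCCCCCCCNC(=O)[C@@H](NC(=O)c1cccs1)[C@@H](C)O` gives 33300 nM in this assay. Compound 3 `CCCCCCCCCCCCCCCCCCNC(=O)[C@@H](NC(=O)c1cc2ccccc2o1)[C@@H](C)O` gives 78800 nM in this assay, the highest number of the three; the two measured steps that lead to it are a 3.9-fold higher number from compound 1 to compound 3 (0.59 log units; beyond the scatter) and a 2.4-fold higher number from compound 2 to compound 3 (0.37 log units; beyond the scatter), both beyond the scatter and both modest.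

Compound 4 `CCCCCCCCCCCCCCCCCCNC(=O)[C@@H](NS(=O)(=O)c1ccc(C)cc1)[C@@H](C)O` differs from compound 3 in one place: (4-methylphenyl)sulfonyl in place of (1-benzofuran-2-yl)carbonyl on an amine nitrogen. Within the data shown here, no measured step covers this kind of exchange, in which a carbonyl-linked group is replaced by a sulfonyl-linked one. Among the measured compounds shown here, the only guidance is that swapping the group on that amine nitrogen, as in the step of a 2.4-fold higher number from compound 2 to compound 3 (0.37 log units; beyond the scatter), shifted the number modestly. A modest step of uncertain direction is therefore expected, and compound 4 is expected to show a 1.6-fold lower number from compound 3 to compound 4 (0.20 log units; within the scatter) in this assay. The expected value for compound 4 is 50000 nM, with a range from 15000 nM to 160000 nM.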

Compound 4, half-maximal inhibitory concentration: 34000 nM
Estimate against measurement, compound 4: 1.5-fold (0.17 log units) above; low and high end bracket the measured number.
By their numbers in this assay, from the lowest: compounds 1, 2 and 4 (each within the scatter of the next); then compound 3.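

On this amine nitrogen, the linking group can change as well as the ring it carries: in this assay, (4-methylphenyl)sulfonyl in place of (1-benzofuran-2-yl)carbonyl gives a 2.3-fold lower number from compound 3 to compound 4 (0.37 log units; beyond the scatter), a modest step. The same sulfonyl group in place of (thiophen-2-yl)carbonyl gives a 1.0-fold higher number from compound 2 to compound 4 (0.01 log units; within the scatter), so the size of the exchange depends on which carbonyl-linked group leaves, at least across these three compounds. No measurement shown here explains the difference between these two exchanges.

As far as these compounds go, it remains open whether a smaller methylsulfonyl group, or a phenylsulfonyl group carrying a carboxylic acid, would read like (4-methylphenyl)sulfonyl on this nitrogen. From the compounds shown here alone, it is also open whether the sulfonyl exchange would give a similar step on the shorter chain of compound 1.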